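Ethoxy in place of acetamido on a biaryl amide

This account rests on a few compounds, and the source may have more. Where it says the series, first, only, none or still open, it means among the compounds named here.

compound 1, `CC(C)N(Cc1cccc(OCCCCCC(=O)O)c1)C(=O)c1ccc(-c2cccc(Br)c2)cc1`: > 26000 nM
compound 2, `CCOC(=O)CCCCCOc1cccc(CN(C(=O)c2ccc(-c3cccc(NC(C)=O)c3)cc2)C(C)C)c1`: > 26000 nM

Of the compounds shown here, two have been measured so far in an ADME assay on Raji cells (Homo sapiens) for cytotoxicity, read by CellTiter-Glo and resazurin assay, with a stated time of 72 h; on this read-out higher numbers stand for an effect only at larger amounts of compound and lower numbers for an effect already at smaller amounts. Compound 1 gives > 26000 nM, which is a limit of the assay and not a number. Compound 2 gives > 26000 nM, likewise a limit rather than a number. Compound 2 therefore stands at the limit of > 26000 nM in this assay, at which 2 of the 2 values shown sit, with no measured number to set it apart from compound 1.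

Compound 3, `CCOC(=O)CCCCCOc1cccc(CN(C(=O)c2ccc(-c3cccc(OCC)c3)cc2)C(C)C)c1`, has not yet been measured. It differs from compound 2 in one place: ethoxy in place of acetamido on an aromatic carbon. Among the compounds with values here, no step between measured compounds is available, so nothing in the data shows how such a change reads in this assay. Given that compound 2 sits at the limit of > 26000 nM in this assay, at which 2 of the 2 values shown sit, the expected step is a number no higher from compound 2 to compound 3 (the limit leaves the size open), none beyond the scatter, and compound 3 is most likely to return a limit again. Compound 3 is estimated at 26000 nM, within 10000 nM to 60000 nM.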

Compound 3, half-maximal effective concentration: > 22300 nM
Compound 3: a limit, no number (the forecaster's own chance of this, stated with the estimate: 75%); the middle value is on the limit's open side.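

Compound 2 and compound 3 both return limits of the assay rather than numbers, so the step between them cannot be read. The compounds shown leave open whether ethoxy in place of acetamido changes the read-out, and at what concentration any of them would show an effect.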